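A few compounds are considered here, and "the series" means these few. Any claim that something is new, unique, unknown or untested is made for them only; others in the source may bear on it.

Values in a functional assay (aorta) with Oryctolagus cuniculus as the target; on this read-out higher numbers stand for weaker binding and lower numbers for tighter binding:
- compound 1 `COc1cc(C(=O)O)ccc1OCCCN1CCC(C(c2ccc(F)cc2)c2ccc(F)cc2)CC1`: 79.4 nM
- compound 2 `COc1cc(C#N)ccc1OCCCN1CCC(C(c2ccc(F)cc2)c2ccc(F)cc2)CC1`: 2 nM
- compound 3 `NC(=O)c1ccc(OCCCN2CCC(C(c3ccc(F)cc3)c3ccc(F)cc3)CC2)cc1`: 31.6 nM

Compound 3 holds the second highest of the three numbers, with a 2.5-fold lower number from compound 1 to compound 3 (0.40 log units; beyond the scatter) and a 16-fold higher number from compound 2 to compound 3 (1.20 log units; beyond the scatter).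

The next compound is compound 4 `N#Cc1ccc(OCCCN2CCC(C(c3ccc(F)cc3)c3ccc(F)cc3)CC2)cc1`, which has cyano in place of carbamoyl on an aromatic carbon.

For the measured compounds named here, no measured step makes exactly this exchange. The closest is a 40-fold lower number from compound 1 to compound 2 (1.60 log units; beyond the scatter), which also places cyano on an aromatic carbon but replaces carboxy. The other relevant step, a 16-fold higher number from compound 2 to compound 3 (1.20 log units; beyond the scatter), runs in the reverse sense and changes 4-cyano-2-methoxyphenyl to 4-carbamoylphenyl, so it differs from the present change by more than one group. Going by the values given here, no measured pair isolates the methoxy group, and compound 2 is the only measured cyano compound. Both steps still favour a lower number for the cyano compound, so a sizeable drop is expected in this assay, probably not the full reverse of the second step. The expected change is a 5.3-fold lower number from compound 3 to compound 4 (0.72 log units; beyond the scatter). The estimate for compound 4 is 6 nM, with an expected range from 1.5 nM to 25 nM.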

Compound 4, dissociation constant: 5.01 nM
The estimate for compound 4 lay 1.2-fold (0.08 log units) above the measured number; the measured number falls inside the stated range.
By their numbers in this assay, from the lowest: compound 2; then compound 4; then compound 3; then compound 1.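

Cyano in place of carbamoyl on an aromatic carbon, para to a large group, is now read on its own in this assay: a 6.3-fold lower number from compound 3 to compound 4 (0.80 log units; beyond the scatter) with no other change, whereas the earlier step to the carbamoyl compound also removed methoxy. The methoxy group also gets its first clean reading, with a 2.5-fold higher number from compound 2 to compound 4 (0.40 log units; beyond the scatter) when hydrogen takes its place, so the nitrile series retains a modest preference for the methoxy compound, and a 16-fold lower number from compound 1 to compound 4 (1.20 log units; beyond the scatter) shows that the 4-cyanophenyl compound still stands well clear of the carboxy compound, although that step changes two features at once. Nothing in hand gives a reason for any of these steps.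

On these data alone, whether methoxy shifts the number to a similar degree alongside carbamoyl or carboxy remains open. So does the response at this position to other groups, such as a sulfonamide or a tetrazole, and to a longer chain on the oxygen.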